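Phenyl in Place of Pyridinyl on a Shared Core

This account rests on a few compounds, and the source may have more. Where it says the series, first, only, none or still open, it means among the compounds named here.

Compound 1 `COc1cccc(OC)c1C(=O)Nc1c[nH]nc1C(=O)Nc1ccncc1` was tested in an ADME assay on MRC5 cells (Homo sapiens) for inhibition, with a stated time of 72 h; on this read-out higher numbers stand for an effect only at larger amounts of compound and lower numbers for an effect already at smaller amounts. In this assay compound 1 gives > 50000 nM, which is a limit of the assay and not a number. Compound 2 `CO[C@H]1CC[C@H](NC(=O)c2n[nH]cc2NC(=O)c2ccc(N3CCCC3)cc2)CC1` shares the core with compound 1, and in this assay compound 2 gives > 50000 nM, again a limit. Compound 3 `COc1cccc(OC)c1C(=O)Nc1c[nH]nc1C(=O)NC1CCN(C(=O)OC(C)(C)C)CC1` gives > 50000 nM in this assay, once more a limit. Among the measured compounds shown here, all three measured compounds therefore sit at the limit of > 50000 nM in this assay, at which 3 of the 3 values shown sit, so no step between two measured numbers exists, and compound 1 can only be placed at that limit alongside the other two.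

Compound 4 `COc1cccc(OC)c1C(=O)Nc1c[nH]nc1C(=O)Nc1ccccc1` has not been measured. It differs from compound 1 in one place: phenyl in place of pyridin-4-yl on an amide-type nitrogen. Because the three measured compounds all sit at the limit of > 50000 nM in this assay, at which 3 of the 3 values shown sit, the step in this assay from compound 1 to compound 4 is expected to be none beyond the scatter, and the expected step is a number no higher from compound 1 to compound 4 (the limit leaves the size open). The estimate for compound 4 in this assay is 50000 nM, expected to lie between 20000 nM and 120000 nM, most likely reported again only as a limit.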

Compound 4, half-maximal effective concentration: > 50000 nM
Compound 4 gave a limit, no number; the forecaster's own chance of this, stated with the estimate: 80%; the middle value sits exactly at the limit.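

In this assay, among the compounds shown here, compound 4 gives > 50000 nM, a limit of the assay and not a number; compound 1 also stands at a limit, so no step between compound 1 and compound 4 can be read. The compounds shown leave open what number any of them would give and whether phenyl and pyridin-4-yl differ at all on the shared core, because all of them stand at one limit: the limit of > 50000 nM in this assay, at which 4 of the 4 values shown sit.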